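Aryl amide series: from compound 3 to compound 4

The source may report more compounds than this note shows. Statements on the series, on what has been measured and on what is new or still open speak of the compounds shown alone.

- Compound 1 `CC(C)c1cccc(NC(=O)CCc2cccc3c2B(O)OC3)c1` gives 510 nM
- Compound 2 `O=C(CCc1cccc2c1B(O)OC2)Nc1cccc(-c2ccccc2)c1` gives 250 nM
- Compound 3 `O=C(CCc1cccc2c1B(O)OC2)Nc1cccc(-c2cccc(F)c2)c1` gives 480 nM

All three values come from a functional assay on SK-OV-3 cells (Homo sapiens) for antiproliferative activity, read by MTT assay, with a stated time of 72 h (on this read-out lower numbers stand for stronger inhibition and higher numbers for weaker inhibition), and form the only measured basis here. Compound 3 lies within the scatter of both other compounds, with a 1.1-fold lower number from compound 1 to compound 3 (0.03 log units; within the scatter) and a 1.9-fold higher number from compound 2 to compound 3 (0.28 log units; within the scatter) on record. Among the compounds with values here, the only step beyond the scatter is a 2.0-fold lower number from compound 1 to compound 2 (0.31 log units; beyond the scatter) and it is modest.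

The change to compound 4 `COc1cc(OC)cc(-c2cccc(NC(=O)CCc3cccc4c3B(O)OC4)c2)c1` is 3,5-dimethoxyphenyl in place of 3-fluorophenyl on an aromatic carbon and it puts 3,5-dimethoxyphenyl in place of 3-fluorophenyl on an aromatic carbon, meta to a large group. The closest evidence is a 1.9-fold higher number from compound 2 to compound 3 (0.28 log units; within the scatter) for fluoro in place of hydrogen, a step within the scatter. Within the data shown here, no measured compound carries a methoxy group, so the data give no direction for this change. In this assay no step beyond the scatter is therefore expected. The estimate amounts to an expected 1.2-fold lower number from compound 3 to compound 4 (0.08 log units; within the scatter) and no more. Compound 4 is estimated at 400 nM with an expected range from 150 nM to 1000 nM for a single measurement.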

Compound 4, half-maximal inhibitory concentration: 44 nM
The estimate for compound 4 lay 9.1-fold (0.96 log units) above the measured number, outside the stated range (below it).
By their numbers in this assay, from the lowest: compound 4; then compounds 2, 3 and 1 (each within the scatter of the next, the first and the last beyond it).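

In this assay this aromatic carbon proves able to carry a large gain: the change gives an 11-fold lower number from compound 3 to compound 4 (1.04 log units; beyond the scatter) and, measured against the unsubstituted ring, a 5.7-fold lower number from compound 2 to compound 4 (0.75 log units; beyond the scatter) in a modest step. The earlier changes did not show this, their largest being a 2.0-fold lower number from compound 1 to compound 2 (0.31 log units; beyond the scatter) in a modest step. The 3,5-dimethoxyphenyl group, with two hydrogen-bond acceptors where 3-fluorophenyl has none, also gives a 12-fold lower number from compound 1 to compound 4 (1.06 log units; beyond the scatter) and so puts compound 4 beyond the scatter of all three other compounds, though nothing at hand bears on the cause of the gain.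

Still open, going by these compounds, is how a phenyl ring with a single methoxy group would compare with the 3,5-dimethoxyphenyl group. Also open, on these data alone, is whether a hydroxyl group, an amine or a carboxylic acid in place of methoxy would keep the gain.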